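Dichlorophenyl Analogue in the Tracheal Functional Assay

The source may report more compounds than this note shows. Statements on the series, on what has been measured and on what is new or still open speak of the compounds shown alone.

Compound 1 `CCN1CC[C@@]2(OC)OC(N)=C(C#N)[C@@H](c3ccccc3)[C@@H]2C1` and compound 2 `CO[C@@]12CCN(Cc3ccccc3)C[C@H]1[C@H](c1ccccc1)C(C#N)=C(N)O2` share one core and differ only in phenyl in place of methyl on a saturated chain carbon bound to an amine nitrogen in a ring. In a functional assay on trachea (Cavia porcellus) (on this read-out lower numbers stand for stronger inhibition and higher numbers for weaker inhibition), compound 1 gives 23400 nM, and compound 2 gives 22600 nM, so a 1.0-fold lower number from compound 1 to compound 2 (0.02 log units; within the scatter). Compound 2 thus stands among the two measured numbers with no separation from compound 1 beyond the scatter. Compound 3 `CO[C@@]12CCN(Cc3ccccc3)C[C@H]1[C@H](c1ccc(Cl)cc1Cl)C(C#N)=C(N)O2` carries 2,4-dichlorophenyl in place of phenyl on a saturated ring carbon. Within the data shown here, no measured step touches this saturated ring carbon, and the only measured step concerns another site and lies within the scatter, so there is no basis for predicting a step beyond the scatter. Compound 3 is therefore expected to sit near compound 2, with a 1.5-fold lower number from compound 2 to compound 3 (0.18 log units; within the scatter), and its estimated value in this assay is 15000 nM, within a range from 4000 nM to 60000 nM.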

Compound 3, half-maximal inhibitory concentration: 18300 nM
Estimate against measurement, compound 3: 1.2-fold (0.09 log units) below; the measured number falls inside the stated range.
By their numbers in this assay, from the lowest: compounds 3, 2 and 1 (each within the scatter of the next).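

Among these compounds, at the saturated ring carbon next to the ring atom that bears a cyano group, which no earlier step had touched, replacing phenyl with 2,4-dichlorophenyl gives a 1.2-fold lower number from compound 2 to compound 3 (0.09 log units; within the scatter) in this assay. Adding the two chlorine atoms to the aromatic ring therefore produces no separation beyond the scatter, so this site now behaves like the amine-nitrogen substituent, where the earlier step also stayed within the scatter. No measurement bearing on the reason for this result is available.

The compounds shown leave open whether an amine on the aromatic ring, or a carboxylic acid in place of the cyano group, would separate from compound 2 beyond the scatter. They also leave open whether a longer chain in place of the methoxy group would do so.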